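The compounds below may be only part of what the source reports. "The series", "measured", "known", "first", "only" and "open" are said of these compounds alone.

Compound 1 `CC1=CS(=O)(=O)c2cc(NC(=O)c3cc([N+](=O)[O-])c(Sc4c(Cl)cncc4Cl)s3)ccc21`: 170 nM
Compound 2 `O=C(Nc1ccc2c(c1)S(=O)(=O)CC2)c1cc([N+](=O)[O-])c(Sc2c(Cl)cncc2Cl)s1`: 130 nM

Both were tested in an assay on isolated protein for inhibition of ubiquitin carboxyl-terminal hydrolase 7 (Homo sapiens); a lower number here means a stronger inhibitor, a higher number a weaker inhibitor. Compound 2 shows the smaller of the two numbers, yet its gap to compound 1 lies within the usual scatter, so the two count as alike. Compound 3 `CC1CS(=O)(=O)c2cc(NC(=O)c3cc([N+](=O)[O-])c(Sc4c(Cl)cncc4Cl)s3)ccc21` has not yet been measured. It differs from compound 2 in one place: methyl in place of hydrogen on a saturated ring carbon. No pair of measured compounds isolates this change, so the data give no reason to expect a shift beyond the scatter in either direction. Compound 3 is expected to give about 150 nM, within 60 nM to 400 nM. The estimated step from compound 2 to compound 3 is a 1.2-fold higher number from compound 2 to compound 3 (0.06 log units; within the scatter).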

Compound 3, half-maximal inhibitory concentration: 75 nM
The estimate for compound 3 lay 2.0-fold (0.30 log units) above the measured number, within the range that was stated.
By their numbers in this assay, from the lowest: compounds 3, 2 and 1 (each within the scatter of the next, the first and the last beyond it).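

In this assay methyl in place of hydrogen on a saturated ring carbon, two ring bonds from the ring sulfur, gives a 1.7-fold lower number from compound 2 to compound 3 (0.24 log units; within the scatter) and so is tolerated at this position, with no loss of inhibition. Among the compounds shown here, this is the first pair of compounds that isolates this single change, and its step does not separate the two compounds. Nothing measured here bears on why the number came out this way.

On these data alone, whether an ethyl chain, a hydroxyl or an amine on this ring carbon would be tolerated as well remains open. The same holds for a second methyl on this carbon.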